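This account rests on a few compounds, and the source may have more. Where it says the series, first, only, none or still open, it means among the compounds named here.

Working notes on the series. The three measured compounds share a bis-sulfonyl aryl core carrying a piperidine, and differ in the piperidine substituent and in whether one sulfonyl is replaced by a sulfoximine. Compound 1 `CCN(CC)S(=O)(=O)c1ccc(S(=O)(=O)N2CCC[C@@H](C(=O)NC3CN(C(=O)OC(C)(C)C)C3)C2)cc1` carries the amide to the azetidine. In a functional assay on MIA PaCa-2 cells (Homo sapiens) for inhibition, read by MTT assay, with a stated time of 3 days (on this read-out lower numbers stand for stronger inhibition and higher numbers for weaker inhibition), compound 1 gives 100 nM, the lowest of the three numbers recorded. Compound 2 `CCOC(=O)[C@@H]1CCCN(S(=N)(=O)c2ccc(S(=O)(=O)N(CC)CC)cc2)C1` carries an ethyl ester and the sulfoximine on the piperidine side; in this assay compound 2 gives 4700 nM, the furthest from compound 1 and beyond the scatter. Compound 3 `CCOC(=O)[C@@H]1CCCN(S(=O)(=O)c2ccc(S(=N)(=O)N(CC)CC)cc2)C1` carries the ester with the sulfoximine on the diethylamide side; in this assay compound 3 gives 900 nM, closer to compound 1 but still beyond the scatter. Compound 2 and compound 3 each differ from compound 1 in more than one place, so no single-point step can be read from them.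

The step to compound 4 `CCN(CC)S(=O)(=O)c1ccc(S(=O)(=O)N2CCC[C@@H](C(=O)N3CCN(c4nc(C)no4)CC3)C2)cc1` changes only the amide substituent: 4-(3-methyl-1,2,4-oxadiazol-5-yl)piperazin-1-yl in place of (1-(tert-butoxycarbonyl)azetidin-3-yl)amino on a carbonyl carbon. Among the measured compounds shown here, no measured pair in the set carries an amide substituent change, so the size of this step is unknown. The amide carbonyl and the core are kept, so the expectation is a step from compound 1 to compound 4 of a 1.5-fold higher number from compound 1 to compound 4 (0.18 log units; within the scatter), small and within or near the scatter, in either direction. In this assay compound 4 is estimated at 150 nM, with a range from 40 nM to 600 nM.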

Compound 4, half-maximal inhibitory concentration: 200 nM
Compound 4: the middle estimate sits 1.3-fold (0.12 log units) below what was measured, within the range that was stated.
By their numbers in this assay, from the lowest: compounds 1 and 4 (each within the scatter of the next); then compound 3; then compound 2.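

In this assay, among the compounds shown here, the first readable step at this position, on a carbonyl carbon, is a 2.0-fold higher number from compound 1 to compound 4 (0.30 log units; within the scatter), with 4-(3-methyl-1,2,4-oxadiazol-5-yl)piperazin-1-yl in place of (1-(tert-butoxycarbonyl)azetidin-3-yl)amino. The position therefore accepts two quite different groups of equal heavy-atom count without a change beyond the scatter, and neither the tert-butoxycarbonyl group, the four-membered ring nor the amide hydrogen is required for a number in this range. No measured evidence bears on the reason for this result.

On these data alone, whether a much smaller group on the carbonyl carbon, such as dimethylamino, or a carboxylic acid in place of the amide would hold this range remains open. As far as these compounds go, the effect of a sulfoximine alongside these amides also remains open, since compound 2 and compound 3 carry it only with the ethyl ester.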